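One aromatic substituent exchanged, clearance expected unchanged

The compounds below may be only part of what the source reports. "The series", "measured", "known", "first", "only" and "open" are said of these compounds alone.

Compound 1 `CCOC(=O)C1=C(C)N/C(=C/c2cc(C)n(-c3ccc(Br)cc3)c2C)C1=O`, compound 2 `CCOC(=O)C1=C(C)N/C(=C/c2cc(C)n(-c3ccc(OC)cc3)c2C)C1=O` and compound 3 `CCOC(=O)C1=C(C)N/C(=C/c2cc(C)n(-c3ccc(SC(F)(F)F)cc3)c2C)C1=O` share one core and differ only in the group on the six-membered aromatic ring of carbon only. In an ADME assay on microsomes from liver (Mus musculus) for metabolic stability, read by LC-MS, tested at 1 uM (on this read-out lower numbers stand for slow clearance and higher numbers for fast clearance), compound 1 gives 62 mL.min-1.g-1, compound 2 gives 54 mL.min-1.g-1 and compound 3 gives 76 mL.min-1.g-1. Compound 3 stands apart from the other two only within the scatter: a 1.2-fold higher number from compound 1 to compound 3 (0.09 log units; within the scatter) and a 1.4-fold higher number from compound 2 to compound 3 (0.15 log units; within the scatter), just as a 1.1-fold lower number from compound 1 to compound 2 (0.06 log units; within the scatter). Compound 4 `CCOC(=O)C1=C(C)N/C(=C/c2cc(C)n(-c3ccc(CN4CCCCC4)cc3)c2C)C1=O` carries (piperidin-1-yl)methyl in place of (trifluoromethyl)sulfanyl on an aromatic carbon. Among the measured compounds shown here, all three measured steps exchange the group at this same place and none moved this assay beyond the scatter, so no step beyond the scatter is expected here, although no measured step involves a group of this kind. The expected step is a 1.1-fold lower number from compound 3 to compound 4 (0.04 log units; within the scatter). Compound 4 is therefore estimated at 70 mL.min-1.g-1, within 35 mL.min-1.g-1 to 140 mL.min-1.g-1.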

Compound 4, intrinsic clearance in microsomes: 60 mL.min-1.g-1
Estimate against measurement, compound 4: 1.2-fold (0.07 log units) above; measured number inside the range.
By their numbers in this assay, from the lowest: compounds 2, 4, 1 and 3 (each within the scatter of the next).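

Putting (piperidin-1-yl)methyl, with its six-membered non-aromatic ring, at this place keeps this assay within the scatter of all three earlier compounds: a 1.3-fold lower number from compound 3 to compound 4 (0.10 log units; within the scatter), a 1.1-fold higher number from compound 2 to compound 4 (0.05 log units; within the scatter) and a 1.0-fold lower number from compound 1 to compound 4 (0.01 log units; within the scatter). The earlier compounds had shown this only for bromo, methoxy and (trifluoromethyl)sulfanyl, so across these four compounds the exchange now extends to a ring-bearing amine with no step beyond the scatter. No measurement given here offers an explanation for this result. The compounds shown leave open whether a carboxylic acid or a longer chain at this place would move the clearance. They also leave open what exchanging the ethyl ester on the shared core would do.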